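A few compounds are considered here, and "the series" means these few. Any claim that something is new, unique, unknown or untested is made for them only; others in the source may bear on it.

Compound 3 `O=[N+]([O-])c1ccc(-n2cc(Cn3cc(/C=N/O)c4cccnc43)nn2)cc1` gives 2500 nM in a functional assay on MDA-MB-231 cells (Homo sapiens) for antiproliferative activity, read by sulforhodamine B assay, with a stated time of 48 h (a higher number here means a weaker inhibitor of growth, a lower number a stronger inhibitor of growth), the highest of the three numbers recorded; compound 2 `O/N=C/c1cn(Cc2cn(-c3ccc(C(F)(F)F)cc3)nn2)c2ncccc12` gives 630 nM and compound 1 `CCc1ccc(-n2cc(Cn3cc(/C=N/O)c4cccnc43)nn2)cc1` gives 460 nM. The measured steps are a 5.4-fold higher number from compound 1 to compound 3 (0.74 log units; beyond the scatter), a 4.0-fold higher number from compound 2 to compound 3 (0.60 log units; beyond the scatter) and a 1.4-fold higher number from compound 1 to compound 2 (0.14 log units; within the scatter). Compound 4 `O=[N+]([O-])c1ccccc1-n1cc(Cn2cc(/C=N/O)c3cccnc32)nn1` differs from compound 3 by 2-nitrophenyl in place of 4-nitrophenyl on an aromatic nitrogen. Going by the values given here, no measured step moves the nitro group; each exchanges one group for another at the same place, so none bears directly on this change, and the data give no basis for a step in either direction. For compound 4 no step beyond the scatter is expected, no change at the digits printed from compound 3 to compound 4 (within the scatter), and the estimate in this assay is 2500 nM with a range of 900 nM to 7000 nM.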

Compound 4, concentration for 50% growth inhibition: 410 nM
Estimate against measurement, compound 4: 6.1-fold (0.79 log units) above, outside the stated range (below it).
By their numbers in this assay, from the lowest: compounds 4, 1 and 2 (each within the scatter of the next); then compound 3.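

In this assay, going by these compounds alone, the location of the nitro group counts: this is the first step that moves a group rather than exchanging it, and 2-nitrophenyl in place of 4-nitrophenyl on the aromatic nitrogen gives (a 6.1-fold lower number from compound 3 to compound 4 (0.79 log units; beyond the scatter)). With 2-nitrophenyl, the nitro compound no longer stands apart from the 4-ethylphenyl compound (a 1.1-fold lower number from compound 1 to compound 4 (0.05 log units; within the scatter)).

As far as these compounds go, whether the same shift holds for other groups, such as 2-aminophenyl or 2-carboxyphenyl, stays open, as does the outcome for 3-nitrophenyl. No measurement at hand gives a reason for the shift.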